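This account rests on a few compounds, and the source may have more. Where it says the series, first, only, none or still open, it means among the compounds named here.

Compound 1, `COc1ccccc1N1CCN(CCCNc2ncccc2C(=O)C2CC2)CC1`, gives 2 nM in a functional assay on aorta for antagonist activity at Alpha-1D adrenergic receptor (Rattus norvegicus); on this read-out higher numbers stand for weaker binding and lower numbers for tighter binding.
Compound 2, `COc1ccccc1N1CCN(CCCOc2ccccc2C(=O)N(C)C)CC1`, gives 31.6 nM.
Compound 3, `CN(C)C(=O)c1cccnc1NCCCN1CCN(c2ccccc2OC(F)(F)F)CC1`, gives 100 nM.

Compound 3 gives the highest number of the three. Compound 2 stands nearest to it with a lower number, a gap beyond the scatter, and compound 1 stands furthest from it, with a much lower number. Compound 4, `CN(C)C(=O)c1cccnc1NCCCN1CCN(c2ccccc2C(F)(F)F)CC1`, differs from compound 3 in one place: trifluoromethyl in place of trifluoromethoxy on an aromatic carbon. Going by the values given here, no measured pair here shows this change, so nothing in the data tells its direction. A step no larger than the usual scatter is expected, a 1.3-fold lower number from compound 3 to compound 4 (0.10 log units; within the scatter), leaning slightly toward a lower number. Compound 4 is therefore estimated at 80 nM, with a range from 25 nM to 250 nM.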

Compound 4, dissociation constant: 316 nM
Beside the measured number, compound 4's estimate is 4.0-fold (0.60 log units) below it; the measured number lies above the stated range.
By their numbers in this assay, from the lowest: compound 1; then compound 2; then compound 3; then compound 4.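

In this assay, going by these compounds alone, compounds 3 and 4 form the first measured pair that differs in one place, and they give this change a direction: trifluoromethyl in place of trifluoromethoxy on an aromatic carbon, ortho to a large group, brings (a 3.2-fold higher number from compound 3 to compound 4 (0.50 log units; beyond the scatter)). The two groups are therefore not interchangeable at this place, at least on this one background. Nothing measured here accounts for the step. From the compounds shown here alone, whether a chlorine atom at this place would give a lower or a higher number stays open, as does whether the same change would hold on the core of compound 1.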